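Swapping the Halogenated Benzyl Group on a Shared Core

The compounds below may be only part of what the source reports. "The series", "measured", "known", "first", "only" and "open" are said of these compounds alone.

Compound 2 `CCCSc1nc(N/N=C(\C)c2ccccc2O)c2nnn(Cc3cccc(Cl)c3)c2n1` sits second highest of the three numbers measured in a functional assay on ECa-109 cells (Homo sapiens) for antiproliferative activity, read by MTT assay, with a stated time of 72 h (a higher number here means a weaker inhibitor, a lower number a stronger inhibitor), where compound 2 gives 13000 nM. Among the measured compounds shown here, compound 1 `CCCSc1nc(N/N=C/c2ccccc2Cl)c2nnn(Cc3ccccc3)c2n1` gives 6180 nM and compound 3 `CCCSc1nc(N/N=C(\C)c2ccccc2)c2nnn(Cc3ccccc3)c2n1` gives 32200 nM; the one single-place step known, a 5.2-fold higher number from compound 1 to compound 3 (0.72 log units; beyond the scatter), changes the aryl on the hydrazone, not the benzyl group. Compound 4 `CCCSc1nc(N/N=C(\C)c2ccccc2O)c2nnn(Cc3ccc(Br)cc3)c2n1` differs from compound 2 as follows: 4-bromophenyl in place of 3-chlorophenyl on a saturated chain carbon bound to an aromatic nitrogen. No measured step changes only this benzyl substituent, so nothing shown speaks directly to it. Compound 4 is therefore expected to stay near compound 2, with no change at the digits printed from compound 2 to compound 4 (within the scatter) not beyond the scatter. The estimate for compound 4 is 13000 nM, within 5000 nM to 35000 nM.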

Compound 4, half-maximal inhibitory concentration: 36100 nM
Beside the measured number, compound 4's estimate is 2.8-fold (0.44 log units) below it; the measured number lies above the stated range.
By their numbers in this assay, from the lowest: compound 1; then compound 2; then compounds 3 and 4 (each within the scatter of the next).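

With the hydrazone side held fixed, this assay shows that this position is not silent: 4-bromophenyl in place of 3-chlorophenyl on a saturated chain carbon bound to an aromatic nitrogen gives a 2.8-fold higher number from compound 2 to compound 4 (0.44 log units; beyond the scatter), a step beyond the scatter. Among the compounds shown here, the earlier step changed only the aryl on the hydrazone, so this is the first reading of the benzyl group alone. No evidence at hand bears on this step. Halogen identity and its place on the ring change together here, and the compounds shown do not separate the two. Going by these compounds, how an amine or a methoxy group on the benzyl ring would read also stays open.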